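Selenium in Place of Sulfur: Expected Cytotoxicity of Compound 4

The source may report more compounds than this note shows. Statements on the series, on what has been measured and on what is new or still open speak of the compounds shown alone.

Of the compounds shown here, three sharing one core have been measured in an ADME assay on BEAS-2B cells (Homo sapiens) for cytotoxicity, read by MTT assay, with a stated time of 72 h; a higher number here means a weaker inhibitor of growth, a lower number a stronger inhibitor of growth. Compound 2 `CSc1nc(NCc2ccccc2)c2ccccc2n1` gives 38900 nM. Compound 1 `C[Se]c1nc(NCc2ccccc2)c2ccccc2n1` gives 570 nM; the change a group of 2 heavy atoms (1 carbon, 1 selenium; no ring) in place of a group of 2 heavy atoms (1 carbon, 1 sulfur; no ring), on an aromatic carbon made a 68-fold lower number from compound 2 to compound 1 (1.83 log units; beyond the scatter). Compound 3 `CSc1ccc(CNc2nc(SC)nc3ccccc23)cc1` gives 22700 nM; it differs from compound 2 by methylsulfanyl in place of hydrogen on an aromatic carbon, and that step was a 1.7-fold lower number from compound 2 to compound 3 (0.23 log units; within the scatter). Compound 4 `CSc1ccc(CNc2nc([Se]C)nc3ccccc23)cc1` has not yet been measured. It differs from compound 3 by a group of 2 heavy atoms (1 carbon, 1 selenium; no ring) in place of a group of 2 heavy atoms (1 carbon, 1 sulfur; no ring), on an aromatic carbon, the same kind of change as from compound 2 to compound 1. The expectation rests on compound 3 at 22700 nM and on the earlier step of a 68-fold lower number from compound 2 to compound 1 (1.83 log units; beyond the scatter). Compound 4 is therefore expected to give 350 nM in this assay, somewhere between 100 nM and 1500 nM, which means an expected step of a 65-fold lower number from compound 3 to compound 4 (1.81 log units; beyond the scatter). A single prior example is a thin base, so the range is kept wide.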

Compound 4, concentration for 50% growth inhibition: 35900 nM
Estimate against measurement, compound 4: 100-fold (2.01 log units) below; measured number above the stated range.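

In this assay, putting the selenium group in place of methylsulfanyl gave a 1.6-fold higher number from compound 3 to compound 4 (0.20 log units; within the scatter), so the large step seen on the core of compound 2 did not carry over to the core of compound 3: the same change on two cores in this assay, a 68-fold lower number (1.83 log units; beyond the scatter) from compound 2 to compound 1 and a 1.6-fold higher number (0.20 log units; within the scatter) from compound 3 to compound 4, 110-fold (2.03 log units) apart, beyond the scatter of two such steps

Read the other way, methylsulfanyl in place of hydrogen on an aromatic carbon gave a 63-fold higher number from compound 1 to compound 4 (1.80 log units; beyond the scatter), which is far from what the same change did in the sulfur pair: the same change on two cores in this assay, a 1.7-fold lower number (0.23 log units; within the scatter) from compound 2 to compound 3 and a 63-fold higher number (1.80 log units; beyond the scatter) from compound 1 to compound 4, 110-fold (2.03 log units) apart, beyond the scatter of two such steps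

The two changes therefore do not act independently across these four compounds, but the data do not show why, and each step rests on a single pair.

As far as these compounds go, it remains open whether a methoxy group, a chlorine atom or an amine in place of that methylsulfanyl would also cancel the selenium step. From the compounds shown here alone, it is equally open whether a longer chain on the selenium would behave as the methyl group does.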